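Methyl at an Aromatic Carbon in Two Amide Acids

A few compounds are considered here, and "the series" means these few. Any claim that something is new, unique, unknown or untested is made for them only; others in the source may bear on it.

Three compounds sharing an anilide carboxylic acid motif have been examined in an assay on isolated protein for agonist activity at Bile acid receptor (Homo sapiens), read by TR-FRET, with a stated time of 3 h, in the absence of a further agent; on this read-out higher numbers stand for an effect only at larger amounts of compound and lower numbers for an effect already at smaller amounts. Compound 1 `COc1ccccc1C(=O)Nc1ccc(C)c(C(=O)O)c1` gives only a limit in this assay, > 10000 nM. Compound 2 `COc1ccccc1C(=O)Nc1cccc(C(=O)O)c1` likewise gives only a limit, > 10000 nM. The change methyl in place of hydrogen on an aromatic carbon therefore yields a step that the two limits leave unreadable from compound 2 to compound 1, which the limit of > 10000 nM in this assay, at which 2 of the 3 values shown sit, leaves unreadable. Among the compounds with values here, compound 3 `O=C(O)c1cccc(NC(=O)c2ccc(OCc3cccc(-c4ccccc4)c3)cc2)c1` is the one compound with a real number, giving 319 nM in this assay; how its core differs from that of compound 2 is not broken down here.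

Compound 4 `Cc1ccccc1-c1cccc(COc2ccc(C(=O)Nc3cccc(C(=O)O)c3)cc2)c1` is not yet measured. It differs from compound 3 by methyl in place of hydrogen on an aromatic carbon, the same kind of change as from compound 2 to compound 1, though the surroundings differ: in compound 1 the methyl sits ortho to a carboxy group and para to a large group, whereas in compound 4 it sits ortho to a large group. The earlier step offers no readable size, so the expectation rests on compound 3 alone at 319 nM, and the expected step is a 1.1-fold lower number from compound 3 to compound 4 (0.03 log units; within the scatter). Compound 4 is thus expected to give about 300 nM, between 120 nM and 800 nM.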

Compound 4, half-maximal effective concentration: 1030 nM
The estimate for compound 4 lay 3.4-fold (0.54 log units) below the measured number; measured number above the stated range.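

In this assay, methyl in place of hydrogen on an aromatic carbon, here phenyl to 2-methylphenyl with the methyl ortho to a large group, gives a 3.2-fold higher number from compound 3 to compound 4 (0.51 log units; beyond the scatter), so on this core the change moves the number upward by a modest but readable step. No size can be set beside it from the core of compound 2, because compound 1 and compound 2 both give only limits and the step between them cannot be read: the limit of > 10000 nM in this assay, at which 2 of the 4 values shown sit. The result therefore shows what the change does on one core only; it does not show whether the effect carries from one core to another, and the methyl also stands in different surroundings in compound 1.

The compounds shown leave open whether this step is specific to methyl, since no other group, such as chlorine, fluorine or ethyl, appears at that place. They also leave open how methyl would behave elsewhere on the same ring of compound 3.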